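Switching the amide nitrogen for sulfur on a thiophene dihydropyrimidinone

A few compounds are considered here, and "the series" means these few. Any claim that something is new, unique, unknown or untested is made for them only; others in the source may bear on it.

Of the compounds shown here, three sharing one core have been measured in an assay on membranes from HeLa cells for displacement of a labelled ligand from adenosine receptor A3 (Homo sapiens), read by scintillation counting, with a stated time of 180 min, tested at 1 uM; a higher number here means more inhibition at the concentration tested (going by the name of the read-out), a lower number less inhibition. Compound 1, `CCNC(=O)C1=C(C)NC(=O)NC1c1cccs1`, gives 4%. Compound 2, `CC1=C(C(=O)NC(C)C)C(c2cccs2)NC(=O)N1`, gives 1%. Compound 3, `CCN(CC)C(=O)C1=C(C)NC(=O)NC1c1cccs1`, gives 31%, the highest of the three numbers, with the steps to both others beyond the scatter. The step from compound 1 to compound 3, a number 27 percentage points higher from compound 1 to compound 3 (beyond the scatter), came with ethyl in place of hydrogen on an amide-type nitrogen; the step from compound 2 to compound 3, a number 30 percentage points higher from compound 2 to compound 3 (beyond the scatter), came with diethylamino in place of isopropylamino on a carbonyl carbon. The step from compound 1 to compound 2, a number 3 percentage points lower from compound 1 to compound 2 (within the scatter), was small.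

Compound 4, `CCSC(=O)C1=C(C)NC(=O)NC1c1cccs1`, is not yet measured. It differs from compound 3 by ethylsulfanyl in place of diethylamino on a carbonyl carbon. Going by the values given here, the change sits at the same carbonyl carbon where the step from compound 2 to compound 3 was measured, and like that step it removes a hydrogen-bearing nitrogen; yet no measured step puts sulfur in place of nitrogen, so the two steps bear on it only loosely. A modest drop is therefore expected, a number 13 percentage points lower from compound 3 to compound 4 (beyond the scatter), as the group entering is smaller than the one leaving. Compound 4 is estimated at 18% in this assay, within a range from 2% to 40%.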

Compound 4, a percentage reported as inhibition, at one concentration (the size of the read-out at that concentration, not a potency): 1%
Compound 4: the middle estimate sits 17 percentage points above what was measured, and the stated range ends above it.
By their numbers in this assay, from the lowest: compounds 2, 4 and 1 (each within the scatter of the next); then compound 3.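

In this assay, putting ethylsulfanyl on this carbonyl carbon gives a number 30 percentage points lower from compound 3 to compound 4 (beyond the scatter), so the higher reading of compound 3 does not carry over to this sulfur-linked group. Going by these compounds alone, until now, the two compounds with an amide hydrogen, compound 1 and compound 2, read low and compound 3, which lacks that hydrogen, read higher, so losing the hydrogen might have seemed enough; compound 4 also has no hydrogen on the atom bound to the carbonyl, yet the comparisons give no change at the digits printed from compound 2 to compound 4 (within the scatter) and a number 3 percentage points lower from compound 1 to compound 4 (within the scatter), which shows that lacking the hydrogen is not enough and leaves diethylamino as the only one of these four groups that stands apart. Nothing available here accounts for the drop.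

The compounds shown leave open whether the higher reading depends on the nitrogen, on its two ethyl chains, or on both, and an ethoxy group or a dipropylamino group on the same carbonyl carbon would help separate these. They also leave open how potent compound 3 is, since its reading comes from a single concentration and is not a measure of potency.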